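The source may report more compounds than this note shows. Statements on the series, on what has been measured and on what is new or still open speak of the compounds shown alone.

For the measured compounds named here, in a functional assay on Bel-7402 cells (Homo sapiens) for inhibition, read by MTT assay, with a stated time of 72 h (on this read-out lower numbers stand for stronger inhibition and higher numbers for weaker inhibition), three compounds have numbers so far. Compound 1 `Nc1ncnc2c1c(-c1cnc3[nH]ccc3c1)nn2CCCCCCCCC(=O)NO` gives 18900 nM and compound 2 `Nc1ncnc2c1c(-c1cnc3[nH]ccc3c1)nn2CCCCCCCCCC(=O)NO` gives 42100 nM. Compound 3 `Nc1nc2cc(-c3nn(CCCCCC(=O)NO)c4ncnc(N)c34)ccc2o1`, which carries a different core, gives 2030 nM, the lowest of the three numbers.

Compound 4 `Nc1nc2cc(-c3nn(CCCCCCC(=O)NO)c4ncnc(N)c34)ccc2o1` keeps the core of compound 3 and changes only the chain end: (hydroxycarbamoyl)methyl in place of hydroxycarbamoyl on a saturated chain carbon, five bonds along the chain from an aromatic nitrogen. Here (hydroxycarbamoyl)methyl stands in place of hydroxycarbamoyl on a saturated chain carbon, five bonds along the chain from an aromatic nitrogen.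

Going by the values given here, only one measured step bears on this change. It is the same swap, made eight bonds along the chain on the other core: a 2.2-fold higher number from compound 1 to compound 2 (0.35 log units; beyond the scatter), a modest step beyond the scatter. One step, on a longer chain and a different core, is thin evidence for the size and direction here.

The step expected in this assay is therefore a small rise, estimated as a 1.5-fold higher number from compound 3 to compound 4 (0.17 log units; within the scatter), and it may stay within the scatter. Compound 4 is expected near 3000 nM, with an estimated range of 900 nM to 9000 nM.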

Compound 4, half-maximal inhibitory concentration: > 50000 nM
Compound 4 was reported as a limit; the forecaster's own chance of this, stated with the estimate: 3%; middle value at least 16-fold (1.22 log units) away from the limit.
By their numbers in this assay, from the lowest: compound 3; then compound 1; then compound 2. At a limit, above all of these: compound 4.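

The swap of hydroxycarbamoyl for (hydroxycarbamoyl)methyl, five bonds along the chain from an aromatic nitrogen, is a large step on the core of compound 3, with an at least 24-fold higher number from compound 3 to compound 4 (1.39 log units; beyond the scatter). The value of compound 4, > 50000 nM, is a limit of the assay and not a number. The same change therefore does not carry the same size from one core to the other: the same change on two cores in this assay, a 2.2-fold higher number (0.35 log units; beyond the scatter) from compound 1 to compound 2 and an at least 24-fold higher number (1.39 log units; beyond the scatter) from compound 3 to compound 4, at least 11-fold (1.04 log units) apart, beyond the scatter of two such steps

The two pairs differ in both core and chain length, so the compounds shown cannot tell which of the two sets this gap. A longer chain on the core of compound 3, or a carboxylic acid in place of hydroxycarbamoyl at the chain end, would show whether the number at this position depends on chain length alone or also on the group at the end.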